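The source may hold more compounds than are shown below. What is called first, only, known or untested is meant among the compounds shown, and "the series" means these compounds.

Of the compounds shown here, two of a shared core have been measured so far. Compound 1 `Nc1nc(Cl)c2ncn(Cc3ccccc3CCl)c2n1` carries an amino group on its six-membered ring, and in a functional assay on MDA-MB-435 cells (Homo sapiens) for cytotoxicity, read by sulforhodamine B assay, with a stated time of 48 h (a higher number here means a weaker inhibitor of growth, a lower number a stronger inhibitor of growth), compound 1 gives 26900 nM. Compound 2 `ClCc1ccccc1Cn1cnc2nc(Cl)nc(Cl)c21` carries a chloro group at that position instead, and in this assay compound 2 gives 30900 nM. Compound 2 therefore stands at the higher of the two numbers, but its value lies within the scatter of that of compound 1, so the two cannot be told apart on these data.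

The next compound, compound 3 `ClCc1ccccc1Cn1cnc2ncnc(Cl)c21`, takes the step from compound 2 in one place: hydrogen in place of chloro on an aromatic carbon. Among the compounds with values here, no step of this kind has yet been measured here, so the expectation rests only on the two values already in hand, which sit close together despite differing at the same position. On that basis the step from compound 2 to compound 3 is expected to be small, a 1.1-fold higher number from compound 2 to compound 3 (0.05 log units; within the scatter), with no change beyond the scatter in either direction. For compound 3 in this assay the value is estimated at 35000 nM, with a range from 12000 nM to 100000 nM.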

Compound 3, concentration for total growth inhibition: 3800 nM
The estimate for compound 3 lay 9.2-fold (0.96 log units) above the measured number; measured number below the stated range.
By their numbers in this assay, from the lowest: compound 3; then compounds 1 and 2 (each within the scatter of the next).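

In this assay, the aromatic carbon between two ring nitrogen atoms turns out to be a place where a single change can shift the number beyond the scatter: with hydrogen in place of chloro, the result is an 8.1-fold lower number from compound 2 to compound 3 (0.91 log units; beyond the scatter). The earlier compounds shown here gave no sign of this, as an amino group in compound 1 gives 26900 nM and a chloro group in compound 2 gives 30900 nM, two values within the scatter of each other, whereas compound 3, with hydrogen at this position, stands at the lowest number of the three at 3800 nM. No measurement among the data shown explains why hydrogen separates from the other two groups here.

The compounds shown leave open whether a methyl, a methoxy or a fluoro group at this position would give a number close to that of compound 3 or one close to those of compound 1 and compound 2. They also leave open whether hydrogen in place of the remaining chloro group, on the same six-membered ring, would bring a step of similar size.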